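This account rests on a few compounds, and the source may have more. Where it says the series, first, only, none or still open, it means among the compounds named here.

Measured in an ADME assay on HEK-293T cells (Homo sapiens) for cytotoxicity, read by luminescence, with a stated time of 24 h; a lower number here means that less compound is tolerated, a higher number that more compound is tolerated:
compound 1 `CCOC(=O)c1cc2sccc2n1Cc1ccc(OC)cc1`: > 100000 nM (a limit)
compound 2 `COc1ccc(Cn2c(C(=O)N3CCCC3)cc3sccc32)cc1`: > 100000 nM (a limit)
compound 3 `CCOC(=O)C1CCN(C(=O)c2cc3sccc3n2Cc2ccc(OC)cc2)CC1`: 39000 nM

Within the data shown here, compound 3 at 39000 nM carries the only number in this set. The values of the other two compounds are limits. The unmeasured compound 4 `COc1ccc(Cn2c(C(=O)N3CCC(C(=O)O)CC3)cc3sccc32)cc1` differs from compound 3 by hydrogen in place of ethyl on an oxygen next to a carbonyl group, which is ethoxycarbonyl to carboxy. Among the measured compounds shown here, no measured step covers this change. For the measured compounds named here, the one step available, a step that the two limits leave unreadable from compound 1 to compound 2, gives no size to carry over. The remaining guide is the limit of > 100000 nM in this assay, at which 2 of the 3 values shown sit. Starting from compound 3 at 39000 nM, a small shift toward more compound tolerated is expected in this assay, not clearly beyond the scatter. A result reported only as a limit is about as likely as a number. The expected step is a 1.8-fold higher number from compound 3 to compound 4 (0.25 log units; within the scatter). For compound 4 the estimate is 70000 nM, with an expected range of 30000 nM to 100000 nM.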

Compound 4, half-maximal cytotoxic concentration: > 100000 nM
Compound 4 was reported as a limit; the forecaster's own chance of this, stated with the estimate: 50%; middle value at least 1.4-fold (0.15 log units) from the limit.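

In this assay, hydrogen in place of ethyl on an oxygen next to a carbonyl group, which is ethoxycarbonyl to carboxy, gives an at least 2.5-fold higher number from compound 3 to compound 4 (0.40 log units; beyond the scatter). Among these compounds, this is the only readable step so far, and it shows that this position can change the read-out; the steps among compound 1, compound 2 and compound 4 cannot be read, as both ends of each are limits. With this change, compound 4 joins the compounds reported at the limit: the limit of > 100000 nM in this assay, at which 3 of the 4 values shown sit.

On these data alone, the true size of the step stays open, as the value of compound 4 is a limit and not a number. Also open, as far as these compounds go, is where a methyl ester, a primary amide or a longer ester chain at this position would fall relative to the ethyl ester and the carboxylic acid.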